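Thiazole to pyridine on the sulfonyl of an EP2 agonist

The source may report more compounds than this note shows. Statements on the series, on what has been measured and on what is new or still open speak of the compounds shown alone.

Measured compounds:
compound 1, `CCCCc1ccc(CN(CCCOc2cccc(C(=O)O)c2)S(C)(=O)=O)cc1` — "not determined" (no result reported)
compound 2, `CC(C)(C)c1ccc(CN(Cc2cccc(CCC(=O)O)c2)S(=O)(=O)c2nccs2)cc1` — 1.1 nM

Two compounds form the starting point. Compound 1, `CCCCc1ccc(CN(CCCOc2cccc(C(=O)O)c2)S(C)(=O)=O)cc1`, carries a methylsulfonyl group on the sulfonamide nitrogen, and in a functional assay on HEK293 cells for agonist activity at prostaglandin E2 receptor EP2 subtype (Rattus norvegicus), read by cAMP accumulation (a lower number here means that less compound is needed, a higher number that more compound is needed for the effect), compound 1 gives "not determined" (no result reported), so no number is reported for it. Among the measured compounds shown here, compound 2, `CC(C)(C)c1ccc(CN(Cc2cccc(CCC(=O)O)c2)S(=O)(=O)c2nccs2)cc1`, is the only one with a number: in this assay compound 2 gives 1.1 nM, so it is the sole reference point and nothing can be said about its standing relative to others.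

Compound 3, `CC(C)(C)c1ccc(CN(Cc2cccc(CCC(=O)O)c2)S(=O)(=O)c2ccccn2)cc1`, differs from compound 2 in one place: pyridin-2-yl in place of 1,3-thiazol-2-yl on a sulfonyl sulfur. For the measured compounds named here, no measured pair shows what this exchange does in this assay, so there is no step to lean on. Given the single anchor, compound 3 is expected to stay close to compound 2, with at most a small loss, a 1.8-fold higher number from compound 2 to compound 3 (0.26 log units; within the scatter), hardly beyond the scatter. The estimate for compound 3 is 2 nM, within a range from 0.7 nM to 6 nM.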

Compound 3, half-maximal effective concentration: 2.3 nM
Compound 3: the middle estimate sits 1.2-fold (0.06 log units) below what was measured; measured number inside the range.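

The sulfonyl sulfur now has its first measured exchange, and it shows that this place tolerates pyridin-2-yl in place of 1,3-thiazol-2-yl at a modest cost in this assay (a 2.1-fold higher number from compound 2 to compound 3 (0.32 log units; beyond the scatter)). The exchange alters ring size and hetero atom count together, swapping a five-membered aromatic ring with 2 hetero atoms for a six-membered one with 1, so this single step cannot separate the two changes. The compounds shown offer no independent evidence to explain the shift.

Going by these compounds, it remains open how a plain phenyl ring, a pyridin-3-yl group or an amine-bearing ring would fare on this sulfonyl sulfur. Compound 1 adds nothing here, as it has no number and differs from compound 2 in more than one place.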